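The compounds below may be only part of what the source reports. "The series", "measured", "known", "first", "only" and "open" are said of these compounds alone.

Measured so far:
compound 1, `CC#C[C@H]1CN(S(=O)(=O)c2ccc(N)nc2)CCN1c1ccc([C@@](O)(CO)C(F)(F)F)cc1`, 89 nM
compound 2, `CC#C[C@H]1CN(S(=O)(=O)c2ccc(N)nc2)CCN1c1ccc(C(C)=O)cc1`, > 12500 nM

In an assay on cells (Hepatocyte) for inhibition of glucokinase regulatory protein (Mus musculus), with stated times of 20 min and 40 min (on this read-out lower numbers stand for an effect already at smaller amounts and higher numbers for an effect only at larger amounts of compound), compound 1 gives 89 nM. Compound 2 reaches only a limit, > 12500 nM, and thus sits at the limit of > 12500 nM in this assay, at which 1 of the 2 values shown sits. Between the two stands an at least 140-fold higher number from compound 1 to compound 2 (2.14 log units; beyond the scatter). Compound 3, `CC#C[C@H]1CN(S(=O)(=O)c2ccc(N)nc2)CCN1c1ccc(C(O)(CC#N)C(F)(F)F)cc1`, differs from compound 2 by a group of 9 heavy atoms (4 carbon, 1 nitrogen, 1 oxygen, 3 fluorine; no ring) in place of a group of 3 heavy atoms (2 carbon, 1 oxygen; no ring), on an aromatic carbon. Only an at least 140-fold higher number from compound 1 to compound 2 (2.14 log units; beyond the scatter) bears on this change, and it was large. Compound 3 restores a trifluoromethyl carbinol, so a large downward step beyond the scatter is expected, an at least 83-fold lower number from compound 2 to compound 3 (1.92 log units; beyond the scatter). For compound 3 the estimate is 150 nM, with a range of 40 nM to 700 nM.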

Compound 3, half-maximal effective concentration: 219 nM
Compound 3: the middle estimate sits 1.5-fold (0.16 log units) below what was measured, within the range that was stated.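

In this assay, a trifluoromethyl carbinol with a nitrile-bearing chain recovers what the acetyl group lacks: an at least 57-fold lower number from compound 2 to compound 3 (1.75 log units; beyond the scatter). The value of compound 2 is only a limit: the limit of > 12500 nM in this assay, at which 1 of the 3 values shown sits. The trifluoromethyl carbinol tolerates a change in its side chain, with the terminal hydroxyl of compound 1 replaced by a nitrile at a modest cost: a 2.5-fold higher number from compound 1 to compound 3 (0.39 log units; beyond the scatter).

As far as these compounds go, it remains open whether the recovery depends on the trifluoromethyl group or on the carbinol hydroxyl. Also open, from the compounds shown here alone, is how an amine or a carboxylic acid would read in place of the nitrile.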